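The source may report more compounds than this note shows. Statements on the series, on what has been measured and on what is new or still open speak of the compounds shown alone.

Three analogues sharing one core have been tested in a functional assay on MCF7 cells (Homo sapiens) for inhibition, read by MTT assay, with a stated time of 72 h; on this read-out higher numbers stand for weaker inhibition and lower numbers for stronger inhibition. Compound 1 `Cc1cc(Nc2ccn(Cc3nc(C)c4ccccc4n3)n2)n2nc(SCc3ccc(Br)cc3)nc2n1` gives 1430 nM. Compound 2 `Cc1cc(Nc2cc(-c3ccccc3)[nH]n2)n2nc(SCc3ccc(C(F)(F)F)cc3)nc2n1` gives 4820 nM, and compound 3 `Cc1ccc(Cn2ccc(Nc3cc(C)nc4nc(SCc5ccc(Br)cc5)nn34)n2)cc1` gives 11300 nM. Among these three numbers, compound 2 stands second highest: its number sits between those of compound 1 and compound 3, nearer to compound 3 than to compound 1, and both gaps lie beyond the scatter. Among the measured compounds shown here, the one measured step, a 7.9-fold higher number from compound 1 to compound 3 (0.90 log units; beyond the scatter), concerns a group on a saturated chain carbon bound to an aromatic nitrogen. Compound 4 `Cc1cc(Nc2cc(-c3ccccc3)[nH]n2)n2nc(SCC(=O)c3ccccc3)nc2n1` differs from compound 2 at another place: benzoyl in place of 4-(trifluoromethyl)phenyl on a saturated chain carbon bound to a sulfur. For the measured compounds named here, no measured step touches the group on the saturated chain carbon bound to a sulfur, so the step on record does not bear on this change, and the numbers so far point neither up nor down. For compound 4 the step in this assay is expected to be a 1.0-fold higher number from compound 2 to compound 4 (0.02 log units; within the scatter), within the scatter. Compound 4 is therefore estimated at 5000 nM, with a likely range from 1500 nM to 16000 nM.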

Compound 4, half-maximal inhibitory concentration: 5240 nM
For compound 4 the middle estimate is 1.0-fold (0.02 log units) below the measured one, within the range that was stated.
By their numbers in this assay, from the lowest: compound 1; then compounds 2 and 4 (each within the scatter of the next); then compound 3.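

In this assay the change to benzoyl from 4-(trifluoromethyl)phenyl on a saturated chain carbon bound to a sulfur gives a 1.1-fold higher number from compound 2 to compound 4 (0.04 log units; within the scatter) and so makes no difference that can be told apart from the scatter. Among the compounds shown here, this is the first reading at this position: for this pair, the group can lose its three fluorine atoms and gain a carbonyl, with its one hydrogen-bond acceptor, and the two compounds still read alike. No measurement shown here explains this result.

On these data alone, both groups contain a six-membered aromatic ring of carbon only, so it remains open whether an amine or a carboxylic acid on the same chain carbon would read alike. Also open, as far as these compounds go, is whether this swap would read the same on compound 1 or compound 3, which carry other groups elsewhere.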